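Methoxy, nitro, azido, then amino: working notes

The compounds below may be only part of what the source reports. "The series", "measured", "known", "first", "only" and "open" are said of these compounds alone.

Values in a functional assay on HCT-116 cells (Homo sapiens) for inhibition, read by CCK-8 assay, with a stated time of 48 h; on this read-out lower numbers stand for stronger inhibition and higher numbers for weaker inhibition:
- Compound 1 `COc1ccc(CN(C(=O)CSC(=S)N2CCN(C(=O)OC(C)(C)C)CC2)c2cc(OC)c(OC)c(OC)c2)cc1OC`: > 20000 nM, a limit of the assay
- Compound 2 `COc1ccc(CN(C(=O)CSC(=S)N2CCN(C(=O)OC(C)(C)C)CC2)c2cc(OC)c(OC)c(OC)c2)cc1[N+](=O)[O-]`: 980 nM
- Compound 3 `COc1ccc(CN(C(=O)CSC(=S)N2CCN(C(=O)OC(C)(C)C)CC2)c2cc(OC)c(OC)c(OC)c2)cc1N=[N+]=[N-]`: 780 nM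

The two numeric values sit together, with no separation beyond the scatter: a 1.3-fold lower number from compound 2 to compound 3 (0.10 log units; within the scatter). Both stand well clear of the limit, as the large steps show: an at least 20-fold lower number from compound 1 to compound 2 (1.30 log units; beyond the scatter) and an at least 25-fold lower number from compound 1 to compound 3 (1.40 log units; beyond the scatter).

Compound 4 `COc1ccc(CN(C(=O)CSC(=S)N2CCN(C(=O)OC(C)(C)C)CC2)c2cc(OC)c(OC)c(OC)c2)cc1N` carries amino in place of azido on an aromatic carbon, ortho to a methoxy group: amino in place of azido on an aromatic carbon. Within the data shown here, no amino step has been measured. The nearest guide is the nitro to azido swap, a 1.3-fold lower number from compound 2 to compound 3 (0.10 log units; within the scatter), while the methoxy steps, such as an at least 25-fold lower number from compound 1 to compound 3 (1.40 log units; beyond the scatter), warn of a possible large loss. A small drift towards a higher number, within the scatter, is therefore expected in this assay. The expected step is a 1.7-fold higher number from compound 3 to compound 4 (0.22 log units; within the scatter). Compound 4 is estimated at 1300 nM, with an expected range of 200 nM to 10000 nM.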

Compound 4, half-maximal inhibitory concentration: 352 nM
The estimate for compound 4 lay 3.7-fold (0.57 log units) above the measured number; measured number inside the range.
By their numbers in this assay, from the lowest: compound 4; then compounds 3 and 2 (each within the scatter of the next). At a limit, above all of these: compound 1.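

In this assay amino separates from the other two replacements at this position, which the nitro and azido pair did not do: a 2.2-fold lower number from compound 3 to compound 4 (0.35 log units; beyond the scatter) and a 2.8-fold lower number from compound 2 to compound 4 (0.44 log units; beyond the scatter). The 3-amino-4-methoxyphenyl compound therefore gives the lowest number of the four, and against methoxy the step reads an at least 56-fold lower number from compound 1 to compound 4 (1.75 log units; beyond the scatter). Compound 1 stands at a limit, so that last step is a bound only: the limit of > 20000 nM in this assay, at which 1 of the 4 values shown sits.

Open, going by these compounds, is whether a methylamino, acetamido or hydroxyl group at this place would match amino. Also open, on these data alone, is whether the hydrogen-bond donor that amino adds and azido lacks has any part in the step.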